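Swapping an Oxygen Linker for Sulfur on a Shared Core

The compounds below may be only part of what the source reports. "The series", "measured", "known", "first", "only" and "open" are said of these compounds alone.

Compound 1 `Nc1cc(N)c2nc(-c3ccccc3)c(Oc3ccc(Cl)c(Cl)c3)nc2c1`: in a functional assay on OVCAR-4 cells (Homo sapiens) for inhibition, read by sulforhodamine B assay, with a stated time of 48 h (on this read-out higher numbers stand for weaker inhibition of growth and lower numbers for stronger inhibition of growth), compound 1 gives < 100000 nM, which is a limit of the measurement and not a number.
Compound 2 `COc1ccc(CNc2nc3cc(N)cc(N)c3nc2-c2ccccc2)cc1OC`: in this assay compound 2 gives 7410 nM.
Compound 3 `CCOC(=O)[C@H](CCC(=O)O)NC(=O)c1ccc(Oc2nc3cc(N)cc(N)c3nc2-c2ccccc2)cc1`: in this assay compound 3 gives < 100000 nM, again a limit rather than a number.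

Three compounds share one core, and each carries a different group on the same aromatic carbon. Compound 1 stands at a limit, and it is not alone there: the limit of < 100000 nM in this assay, at which 2 of the 3 values shown sit. Only compound 2 yields an actual number, so there is no measured step between any two of these compounds to lean on, and nothing can be said about which group helps or hurts.

Compound 4 `Nc1cc(N)c2nc(-c3ccccc3)c(Sc3ccc(Cl)c(Cl)c3)nc2c1` has not yet been measured. It differs from compound 1 in one place: (3,4-dichlorophenyl)sulfanyl in place of 3,4-dichlorophenoxy on an aromatic carbon. For the measured compounds named here, with compound 1 sitting at a limit and no measured step to guide the size of such a swap, the expected change from compound 1 to compound 4 is none beyond the usual scatter, a step that the limit leaves unreadable from compound 1 to compound 4. Compound 4 is therefore expected to come out near 60000 nM, somewhere between 10000 nM and 100000 nM, quite possibly as another limit.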

Compound 4, concentration for total growth inhibition: < 100000 nM
Compound 4: no number, only a limit (the forecaster's own chance of this, stated with the estimate: 65%); the middle value is on the limit's open side.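

In this assay compound 4 gives < 100000 nM as a limit of the measurement and not a number. For the compounds shown here, compound 1 also stands at a limit, and no step between compound 1 and compound 4 can be read. As far as these compounds go, whether (3,4-dichlorophenyl)sulfanyl or 3,4-dichlorophenoxy on the shared core goes with stronger inhibition of growth stays open.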